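Anilino-enone analogues: from dimethoxyphenyl to fluorophenyl

This account rests on a few compounds, and the source may have more. Where it says the series, first, only, none or still open, it means among the compounds named here.

Measured compounds:
- compound 1 `COc1ccc(N/C=C\C(=O)c2nc(-c3ccc(C(F)(F)F)cc3)n3ccccc23)cc1OC`: > 30000 nM
- compound 2 `O=C(/C=C\Nc1cnc2ccccc2c1)c1nc(-c2ccccc2)n2ccccc12`: > 30000 nM
- compound 3 `COc1ccc(-c2nc(C(=O)/C=C\Nc3ccc(Cl)cc3)c3ccccn23)cc1`: "not determined" (no result reported)

Three compounds with a shared core were tested in a functional assay on A549 cells (Homo sapiens) for cytotoxicity, read by MTT assay, with a stated time of 48 h; on this read-out higher numbers stand for weaker inhibition and lower numbers for stronger inhibition. For compound 1 the result is only a limit of the assay, > 30000 nM, and not a number. For compound 2 the result is likewise a limit, > 30000 nM. For compound 3 the entry in this assay reads "not determined" (no result reported). So compound 1 stands where two of the three entries do: at the limit (the limit of > 30000 nM in this assay, at which 2 of the 3 values shown sit), which means its potency could not be told within the range the assay covers.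

Compound 4 `O=C(/C=C\Nc1ccc(F)cc1)c1nc(-c2ccc(C(F)(F)F)cc2)n2ccccc12` is not yet measured. It differs from compound 1 in one place: 4-fluorophenyl in place of 3,4-dimethoxyphenyl on an amine nitrogen. Within the data shown here, no measured pair of compounds differs in this way, so no measured step shows what this exchange does. Since compound 1 sits at the limit of the assay, with > 30000 nM, a change in either direction may stay hidden; the expectation is that compound 4 also shows no measurable inhibition, and the expected step from compound 1 to compound 4 is a number no higher from compound 1 to compound 4 (the limit leaves the size open). The estimate for compound 4 in this assay is 30000 nM, with a range from 10000 nM to 100000 nM.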

Compound 4, half-maximal inhibitory concentration: > 30000 nM
Compound 4: no number, only a limit; the forecaster's own chance of this, stated with the estimate: 80%; the middle value sits exactly at the limit.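

Compound 4, like compound 1, gives only a limit of the assay and not a number, so no step between these two compounds can be read: the limit of > 30000 nM in this assay, at which 3 of the 4 values shown sit.

The compounds shown leave open whether 4-fluorophenyl in place of 3,4-dimethoxyphenyl on the amine nitrogen changes potency at all, and what change to the shared core would bring a measurable value.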